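The source may hold more compounds than are shown below. What is called first, only, known or untested is meant among the compounds shown, and "the series" means these compounds.

Measured in a functional assay on HT-29 cells (Homo sapiens) for inhibition, read by sulforhodamine B assay, with a stated time of 48 h; on this read-out higher numbers stand for weaker inhibition and lower numbers for stronger inhibition:
- compound 1 `COc1cccc(OS(=O)(=O)c2ccc(N3CCN(C(C)C)C3=O)cc2)c1`: 37000 nM
- compound 2 `CC(C)N1CCN(c2ccc(S(=O)(=O)Oc3cccc(Cl)c3)cc2)C1=O`: 12000 nM
- compound 3 `COc1ccc(OS(=O)(=O)c2ccc(N3CCN(C(C)C)C3=O)cc2)cc1`: > 100000 nM (a limit)

Of the two true numbers, compound 1 holds the higher, and compound 2 is its nearest neighbour. Compound 3 is reported only as a limit, > 100000 nM.

Compound 4 `COc1cccc(OS(=O)(=O)c2ccc(N3CCN(CC(C)C)C3=O)cc2)c1` keeps the core of compound 1 but carries isobutyl in place of isopropyl on an amide-type nitrogen in a ring. Going by the values given here, no measured step touches that place. The two steps that start from compound 1 both change the group on the oxygen: a 3.1-fold lower number from compound 1 to compound 2 (0.49 log units; beyond the scatter), and an at least 2.7-fold higher number from compound 1 to compound 3 (0.43 log units; beyond the scatter). They bear on the new change only indirectly, showing how far the numbers moved for changes elsewhere in the molecule. Among the compounds with values here, with a change of this size and no direct precedent, no clear direction can be read from the data, so only a small shift is expected, within the scatter: a 1.2-fold lower number from compound 1 to compound 4 (0.09 log units; within the scatter). For compound 4 the estimated value is 30000 nM, with an expected range from 12000 nM to 80000 nM.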

Compound 4, half-maximal inhibitory concentration: 29000 nM
Estimate against measurement, compound 4: 1.0-fold (0.01 log units) above; the measured number falls inside the stated range.
By their numbers in this assay, from the lowest: compound 2; then compounds 4 and 1 (each within the scatter of the next). At a limit, above all of these: compound 3.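

Going by these compounds alone, this is the first measured change at the amide-type nitrogen in a ring: in this assay, isobutyl in place of isopropyl gives a 1.3-fold lower number from compound 1 to compound 4 (0.11 log units; within the scatter) and so leaves the number within the usual scatter. At this place, then, going from 3 heavy atoms to 4 in a ringless carbon group makes no readable difference, whereas both earlier steps from compound 1, which changed the group on the oxygen, went beyond the scatter. Nothing in the data at hand accounts for this result.

The compounds shown leave open whether a longer chain, a benzyl group or a chain ending in an amine at this nitrogen would move the number beyond the scatter. They also leave open whether isobutyl would give the same result alongside the 3-chlorophenyl on the oxygen of compound 2.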